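A few compounds are considered here, and "the series" means these few. Any claim that something is new, unique, unknown or untested is made for them only; others in the source may bear on it.

Measured compounds in an assay on U2OS cells for activation of nuclear factor erythroid 2-related factor 2 (Homo sapiens), read by chemiluminescence, with a stated time of 6 h; a higher number here means that more compound is needed for the effect, a lower number that less compound is needed:

compound 1 `COc1cccc(S(=O)(=O)/C=C/c2ccccn2)c1`: 2170 nM
compound 2 `COc1cccc(S(=O)(=O)/C=C/c2ncccc2F)c1`: 444 nM

Compound 2 gives the lower of the two numbers in this assay, and the gap to compound 1, a 4.9-fold lower number from compound 1 to compound 2 (0.69 log units; beyond the scatter), is beyond the scatter. That step exchanges fluoro for hydrogen on an aromatic carbon of the six-membered aromatic ring with one nitrogen, two atoms from the ring nitrogen.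

Compound 3 `COc1cccc(S(=O)(=O)/C=C/c2ncccc2Cl)c1` has not been measured. It differs from compound 2 in one place: chloro in place of fluoro on an aromatic carbon. The halogen sits on the same carbon as the fluoro of compound 2, ortho to a large group, two atoms from the ring nitrogen.

Going by the values given here, no measured step concerns the exchange of one halogen for another; the only step on record, from hydrogen to fluoro, compares a bare carbon with a substituted one and says nothing direct about the size of the halogen at that carbon. For compound 3 the step of a 1.1-fold lower number from compound 2 to compound 3 (0.05 log units; within the scatter) is therefore expected to stay within the scatter, with the range kept wide. The estimate for compound 3 in this assay is 400 nM, between 150 nM and 1200 nM.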

Compound 3, half-maximal effective concentration: 98 nM
Beside the measured number, compound 3's estimate is 4.1-fold (0.61 log units) above it; measured number outside the range, below it.
By their numbers in this assay, from the lowest: compound 3; then compound 2; then compound 1.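

In this assay the carbon two atoms from the ring nitrogen responds to which halogen it carries, not only to whether it carries one: chloro in place of fluoro gives a 4.5-fold lower number from compound 2 to compound 3 (0.66 log units; beyond the scatter) and thus a step of its own. Measured against the bare carbon, chloro goes further, with a 22-fold lower number from compound 1 to compound 3 (1.35 log units; beyond the scatter), so the numbers at this one carbon fall in the order hydrogen, fluoro, chloro, and none of the three compounds goes against that order. Nothing at hand accounts for the difference between the two halogens.

As far as these compounds go, whether the order continues with bromo or iodo, or whether a non-halogen such as methyl or nitrile on the same carbon gives a comparable number, stays open, since three compounds trace only one short series at one position. Also open, from the compounds shown here alone, is whether the gain from chloro carries over when the shared core changes elsewhere, for instance with an amine in place of the methoxy group.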